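A few compounds are considered here, and "the series" means these few. Any claim that something is new, unique, unknown or untested is made for them only; others in the source may bear on it.

Measured compounds: compound 1 `O=C(Oc1ccc(Cl)cc1OC(=O)c1ccccc1O)c1ccccc1O`, 51.6%; compound 2 `COc1cccc(OC(=O)c2cccc(O)c2)c1OC(=O)c1cccc(O)c1`, 79%.

In a functional assay on NCI-H1299 cells (Homo sapiens) for inhibition, read by scintillation counting, with a stated time of 30 min, tested at 30 uM (a higher number here means more inhibition at the concentration tested (going by the name of the read-out), a lower number less inhibition), compound 2 gives 79%, the higher of the two numbers. Its nearest neighbour is compound 1, which in this assay gives 51.6%, a gap beyond the scatter. Compound 3 `O=C(Oc1cccc(OC(=O)c2cccc(O)c2)c1OC(=O)c1cccc(O)c1)c1cccc(O)c1` differs from compound 2 by (3-hydroxyphenyl)carbonyl in place of methyl on an oxygen on an aromatic ring. Among the measured compounds shown here, no measured pair shows this change, so no step beyond the scatter is expected in this assay, in either direction. Compound 3 is expected to give about 75%, within 50% to 95%. The step expected a number 4 percentage points lower from compound 2 to compound 3 (within the scatter) is small.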

Compound 3, a percentage reported as inhibition, at one concentration (the size of the read-out at that concentration, not a potency): 99.7%
Compound 3: middle estimate off by 24.7 percentage points, on the low side, outside the stated range (above it).
By their numbers in this assay, from the lowest: compound 1; then compound 2; then compound 3.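

In this assay, the exchange of methoxy for ((3-hydroxyphenyl)carbonyl)oxy gives a number 20.7 percentage points higher from compound 2 to compound 3 (beyond the scatter). This position on the shared core therefore accepts a much larger group, one that adds an aromatic ring and a carbonyl, without loss of inhibition at the concentration tested, and the number rises instead. Nothing at hand bears on the reason for this rise. On these data alone, whether the hydroxyl on the entering ring or its carbonyl is needed remains open. So does what a plain acetyl, an amine or a carboxylic acid-bearing chain on this oxygen would give.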